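The source may hold more compounds than are shown below. What is called first, only, known or untested is meant among the compounds shown, and "the series" means these compounds.

Compound 1 `O=C(O)CCNC(=O)c1ccc2c(c1)C(=O)N(CCC1CCNCC1)C2` and compound 2 `CS(=O)(=O)N[C@@H](CNC(=O)c1ccc2c(c1)C(=O)N(CCC1CCNCC1)C2)C(=O)O` share one core and differ at a single saturated chain carbon. In a functional assay for inhibition, with Homo sapiens as the target (a lower number here means a stronger inhibitor, a higher number a weaker inhibitor), compound 1 gives 27 nM, the highest of the two numbers available, and compound 2 gives 14 nM. The step of a 1.9-fold lower number from compound 1 to compound 2 (0.29 log units; within the scatter), which put methanesulfonamido in place of hydrogen, stayed within the scatter. Compound 3 `O=C(NC[C@H](NS(=O)(=O)c1cccnc1)C(=O)O)c1ccc2c(c1)C(=O)N(CCC1CCNCC1)C2` has not yet been measured; it differs from compound 1 by ((pyridin-3-yl)sulfonyl)amino in place of hydrogen on a saturated chain carbon bound to a carbonyl carbon and a saturated chain carbon. Within the data shown here, the only step that bears on this change is a 1.9-fold lower number from compound 1 to compound 2 (0.29 log units; within the scatter), where a related sulfonyl-bearing group entered at the same place without moving the number beyond the scatter. For compound 3 the expected step is therefore a 1.7-fold lower number from compound 1 to compound 3 (0.23 log units; within the scatter), a small change with no direction that can be trusted beyond the scatter. Compound 3 is estimated in this assay at 16 nM, with a range from 6 nM to 45 nM.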

Compound 3, half-maximal inhibitory concentration: 15 nM
Compound 3: the middle estimate sits 1.1-fold (0.03 log units) above what was measured, and the stated range covers the measured number.
By their numbers in this assay, from the lowest: compounds 2, 3 and 1 (each within the scatter of the next).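

Putting ((pyridin-3-yl)sulfonyl)amino on this saturated chain carbon gives a 1.8-fold lower number from compound 1 to compound 3 (0.26 log units; within the scatter) in this assay, so a sulfonyl-bearing group that carries a six-membered aromatic ring also leaves the number within the scatter of the compound without any group there. Replacing methyl with pyridin-3-yl on the sulfonyl sulfur gives a 1.1-fold higher number from compound 2 to compound 3 (0.03 log units; within the scatter), so this assay does not separate the two sulfonyl groups, even though one is much larger than the other. Nothing available accounts for these small steps.

On these data alone, it remains open whether the sulfonyl is needed at all, since a plain amine or an acetylamino group at this carbon would test that. The compounds shown also leave open what happens with a phenyl on the sulfur, or with an ester replacing the carboxylic acid.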